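Cytotoxicity limits and a chloro for methoxy swap

A few compounds are considered here, and "the series" means these few. Any claim that something is new, unique, unknown or untested is made for them only; others in the source may bear on it.

In an ADME assay on HepG2 cells (Homo sapiens) for cytotoxicity, read by luminescence, with a stated time of 72 h (a higher number here means that more compound is needed for the effect, a lower number that less compound is needed), compound 1 `CCOC(=O)c1c(-c2cccc(Cl)c2)[nH]c2cc(OC)ccc2c1=O`, which carries 3-chlorophenyl, gives > 21500 nM, a limit of the assay and not a number. Compound 2 `CCOC(=O)c1c(-c2cccc(OC)c2)[nH]c2cc(OC)c(Cl)cc2c1=O` gives > 21500 nM, likewise only a limit. Among the compounds with values here, compound 2 therefore has no exact value, and the only other value is a limit too. Compound 3 `CCOC(=O)c1c(-c2cccc(Cl)c2)[nH]c2cc(OC)c(Cl)cc2c1=O` follows from compound 2 by chloro in place of methoxy on an aromatic carbon, 3-methoxyphenyl to 3-chlorophenyl. Within the data shown here, no measured step covers this change. In this assay, nothing beyond the scatter is expected, with a step that the limit leaves unreadable from compound 2 to compound 3 as the estimate. Compound 3 is estimated at 25000 nM, with an expected range of 12000 nM to 50000 nM.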

Compound 3, half-maximal effective concentration: > 21500 nM
Compound 3: a limit, no number; the forecaster's own chance of this, stated with the estimate: 80%; the middle value does not contradict the limit.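

No step can be read from compound 1 or compound 2 to compound 3, since each compound gives only a limit and not a number: the limit of > 21500 nM in this assay, at which 3 of the 3 values shown sit.

The compounds shown leave open whether chloro in place of methoxy or hydrogen changes the result in this assay at all.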